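The source may report more compounds than this note shows. Statements on the series, on what has been measured and on what is new or still open speak of the compounds shown alone.

Measured compounds:
compound 1, `CN(C)/N=N\c1ccnc2cc(Br)ccc12`: -8.9%
compound 2, `CN(C)/N=N\c1ccnc2ccc(I)cc12`: 10.5%

Both were tested in a toxicity assay on the whole organism (P388 cells) for cytotoxicity, with Mus musculus as the target, with a stated time of 9 days, at a dose of 40 mg/kg by the intraperitoneal route; on this read-out lower numbers stand for a stronger effect and higher numbers for a weaker effect at the one dose given. Compound 2 gives 10.5%, the highest of the two numbers shown. Within the data shown here, compound 1 gives -8.9%, a number lower by more than the usual scatter of this read-out, so at the one dose given compound 1 shows the stronger effect of the pair. Compound 3, `CN(C)/N=N\c1ccnc2ccc(Br)cc12`, has not yet been measured in this assay. It differs from compound 2 in one place: bromo in place of iodo on an aromatic carbon. One halogen simply takes the place of another at the same spot. Among the measured compounds shown here, no measured pair in this set shows what such a swap does here. The expected step is small, perhaps slightly toward a lower number but within the usual scatter, a number 5.5 percentage points lower from compound 2 to compound 3 (within the scatter). Compound 3 is therefore estimated at 5%, with a range from -15% to 25%.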

Compound 3, a percentage reported as activity, at one dose (the size of the read-out at that dose, not a potency): -3.5%
For compound 3 the middle estimate is 8.5 percentage points above the measured one; measured number inside the range.
By their numbers in this assay, from the lowest: compounds 1 and 3 (each within the scatter of the next); then compound 2.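

Replacing iodo with bromo on this aromatic carbon gives a number 14 percentage points lower from compound 2 to compound 3 (beyond the scatter) in this assay and, on this read-out, that means a stronger effect at the one dose given. The step is modest, yet it shows that the choice of halogen at this spot matters here, even though one atom simply takes the place of another and no ring, hydrogen-bond donor, hydrogen-bond acceptor or net charge enters or leaves. Nothing measured alongside these numbers explains the step.

From the compounds shown here alone, whether chloro, or a group of another kind such as an amine or a methoxy group, on this same carbon would lower the number further or raise it remains open. This reading also rests on a single pair of compounds, so it is unclear whether the same swap would have a similar effect elsewhere on the shared core.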